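Halogen Swaps in a Piperazine Imide Series in Mice

The source may report more compounds than this note shows. Statements on the series, on what has been measured and on what is new or still open speak of the compounds shown alone.

Compound 1, `O=C1CC(c2ccccc2F)C(=O)N1CN1CCN(c2ccc(F)cc2)CC1`: in a functional assay on the whole organism (strain CF-1 albino) with Mus musculus as the target, with a stated time of 4 h (a lower number here means that less compound is needed, a higher number that more compound is needed for the effect), compound 1 gives 30 mg/kg.
Compound 2, `O=C1CC(c2ccccc2F)C(=O)N1CN1CCN(c2ccc(Cl)cc2)CC1`: in this assay compound 2 gives 100 mg/kg.
Compound 3, `O=C1CC(c2ccccc2Br)C(=O)N1CN1CCN(c2ccc(F)cc2)CC1`: in this assay compound 3 gives 100 mg/kg.

Compound 3 stands level with compound 2 at the digits given, the two together showing the highest numbers of the three, and it sits furthest from compound 1: a 3.3-fold higher number from compound 1 to compound 3 (0.52 log units; beyond the scatter). That step came from bromo in place of fluoro on an aromatic carbon. The other measured step, a 3.3-fold higher number from compound 1 to compound 2 (0.52 log units; beyond the scatter), came from chloro in place of fluoro on an aromatic carbon, on the phenyl attached to the amine nitrogen in a ring.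

Compound 4, `O=C1CC(c2ccccc2Br)C(=O)N1CN1CCN(c2cccc(Cl)c2)CC1`, differs from compound 3 in one place: 3-chlorophenyl in place of 4-fluorophenyl on an amine nitrogen in a ring. Going by the values given here, of the measured steps, only a 3.3-fold higher number from compound 1 to compound 2 (0.52 log units; beyond the scatter) touches the same place, and it was modest; no measured compound carries a 3-chlorophenyl, so the move of the chloro to a different position is untested here. The account therefore expects a higher number for compound 4 than for compound 3, a step of about a 2.0-fold higher number from compound 3 to compound 4 (0.30 log units; within the scatter), with wider uncertainty than the scatter. Compound 4 is expected to give 200 mg/kg in this assay, within a range of 70 mg/kg to 600 mg/kg.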

Compound 4, minimum effective dose: 100 mg/kg
Estimate against measurement, compound 4: 2.0-fold (0.30 log units) above; low and high end bracket the measured number.
By their numbers in this assay, from the lowest: compound 1; then compounds 2, 3 and 4 (each within the scatter of the next).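

The swap of 4-fluorophenyl for 3-chlorophenyl on the amine nitrogen in a ring gives no change at the digits printed from compound 3 to compound 4 (within the scatter) in this assay, so with the core of compound 3 this position accepts a chloro-bearing phenyl without a step beyond the scatter. Going by these compounds alone, the only earlier step at this position, a 3.3-fold higher number from compound 1 to compound 2 (0.52 log units; beyond the scatter), was beyond the scatter, but it was read with the core of compound 1 and with a different placement of the chloro, so the two steps do not describe the same change. The new result therefore shows that a chlorine on this phenyl does not bring a step beyond the scatter in every setting among these compounds, and nothing available here offers an explanation for the difference between the two steps.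

The compounds shown leave open how 3-chlorophenyl would behave with the core of compound 1, and whether the outcome at this position depends on the halogen on the other aromatic ring. They also leave open what this assay would show with an unsubstituted phenyl, a methoxyphenyl or a pyridyl on the same amine nitrogen.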